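Tightening the Amine into a Four-Membered Ring

The compounds below may be only part of what the source reports. "The series", "measured", "known", "first", "only" and "open" are said of these compounds alone.

Compound 1, `CC(C)N(C)c1ncnc2c1ncn2CC1CC1`: 32%
Compound 2, `CCN(CC)c1ncnc2c1ncn2CC1CC1`: 0%

Of the compounds shown here, two sharing one core have been measured in a functional assay on the whole organism for inhibition, with Rattus norvegicus as the target, at a dose of 25 mg/kg by the intraperitoneal route; on this read-out higher numbers stand for more inhibition at the one dose given (going by the name of the read-out) and lower numbers for less inhibition. For the measured compounds named here, compound 2 stands lowest of the two numbers; its nearest neighbour is compound 1, and the only measured step, a number 32 percentage points lower from compound 1 to compound 2 (beyond the scatter), is large and lies beyond the scatter. It shows that the amine on this aromatic carbon matters: swapping one open-chain amine for another was enough to take the read-out down to nothing.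

Compound 3, `c1nc(N2CCC2)c2ncn(CC3CC3)c2n1`, is not yet measured. It differs from compound 2 by azetidin-1-yl in place of diethylamino on an aromatic carbon. Here the two open chains are closed into a small ring, so the group is smaller and held rigid. Going by the values given here, the single measured step bears on this change only in a loose way, since it compared two open-chain amines and neither was a ring. With one step of that size and compound 2 at the floor, a rise is plausible, but the evidence is thin. The expected step is a number 15 percentage points higher from compound 2 to compound 3 (beyond the scatter), a modest gain. Compound 3 is estimated at 15%, within a range from 0% to 40%.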

Compound 3, a percentage reported as inhibition, in the whole organism at one dose (the size of the read-out at that dose, not a potency): 30%
The estimate for compound 3 lay 15 percentage points below the measured number; the range from low to high includes it.
By their numbers in this assay, from the lowest: compound 2; then compounds 3 and 1 (each within the scatter of the next).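

In this assay, azetidin-1-yl in place of diethylamino on this aromatic carbon brings a number 30 percentage points higher from compound 2 to compound 3 (beyond the scatter) and so shows that a small closed ring can stand at this position without the read-out dropping to nothing. Against the other open-chain amine the picture is level, with a number 2 percentage points lower from compound 1 to compound 3 (within the scatter) for azetidin-1-yl in place of isopropyl(methyl)amino, so closing a ring is not in itself what matters: among these three amines, diethylamino is the one that stands apart, while the open-chain isopropyl(methyl)amino and the ring cannot be told apart. Nothing available here explains why these amines behave differently.

A larger ring such as pyrrolidin-1-yl or piperidin-1-yl, or a shorter open-chain amine such as dimethylamino, could show whether the read-out follows the size of the amine or whether the loss is particular to diethylamino. The read-out also comes from a single dose, so these numbers leave open how the compounds compare in potency.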